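Dimethylamino for acetyl on the pendant phenyl ring

The source may hold more compounds than are shown below. What is called first, only, known or untested is meant among the compounds shown, and "the series" means these compounds.

Compound 1 `COc1cc(C)cc(-c2c(-c3ccnc(-c4ccc(C(C)=O)cc4)c3)cnn2CC#N)c1` stands at the edge of the measured range in a functional assay on SNB-19 cells (Homo sapiens) for inhibition, read by sulforhodamine B assay, with a stated time of 48 h; on this read-out higher numbers stand for weaker inhibition of growth and lower numbers for stronger inhibition of growth. Compound 1 gives > 100000 nM, which is a limit of the assay and not a number (the limit of > 100000 nM in this assay, at which 1 of the 2 values shown sits). Compound 2 `COc1cc(C)cc(-c2nn(CC#N)cc2-c2ccnc(-c3ccc(N(C)C)cc3)c2)c1` gives 567 nM in this assay. Compound 3 `COc1cc(C)cc(-c2c(-c3ccnc(-c4ccc(N(C)C)cc4)c3)cnn2CC#N)c1` differs from compound 1 by dimethylamino in place of acetyl on an aromatic carbon. Within the data shown here, no measured step of this kind exists. The step of an at least 66-fold lower number from compound 1 to compound 3 (1.82 log units; beyond the scatter) is expected to be large, toward stronger inhibition of growth. Compound 3 is estimated at 1500 nM, between 250 nM and 20000 nM, because compound 2 carrying the same dimethylamino group gives 567 nM.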

Compound 3, concentration for 50% growth inhibition: 362 nM
Compound 3: middle estimate off by 4.1-fold (0.62 log units), on the high side, and the stated range covers the measured number.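

In this assay, among these compounds, going from 4-acetylphenyl to 4-(dimethylamino)phenyl gives an at least 270-fold lower number from compound 1 to compound 3 (2.44 log units; beyond the scatter), the first measured step at this position, and it shows that this single exchange on an otherwise unchanged core is enough to bring growth inhibition into the measurable range. Compound 1 gives > 100000 nM, which is a limit of the assay and not a number, and the true size of the step stays unknown: the limit of > 100000 nM in this assay, at which 1 of the 3 values shown sits.

Open, as far as these compounds go, is whether a primary amine or morpholine at this position would match dimethylamino. Also open, from the compounds shown here alone, is how a carboxylic acid would compare with acetyl there.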